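The compounds below may be only part of what the source reports. "The series", "measured", "known", "first", "only" and "open" are said of these compounds alone.

Working notes on the series.

Three compounds of the shared core carry measured numbers. Compound 1 `COc1cc(Cc2nc3c(N)ncnc3n2CCO)cc(OC)c1OC` gives 222000000 nM in a functional assay on MCF7 cells (Homo sapiens) for cytotoxicity; on this read-out higher numbers stand for an effect only at larger amounts of compound and lower numbers for an effect already at smaller amounts. Within the data shown here, compound 2 `COc1cc(Cc2nc3c(N)ncnc3n2CCCCCO)cc(OC)c1OC` gives 84900000 nM in this assay, and the single measured step, a 2.6-fold lower number from compound 1 to compound 2 (0.42 log units; beyond the scatter), is the only change in the set that lies beyond the scatter. Compound 3 `CCCCCCn1c(Cc2cc(OC)c(OC)c(OC)c2)nc2c(N)nc(F)nc21` gives 112000000 nM in this assay; on the numbers at hand it stands second highest of three, its gaps to compound 2 and to compound 1 both falling within the scatter, so no order among these three is claimed.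

Compound 4 `COc1cc(Cc2nc3c(N)nc(F)nc3n2CC2CCCO2)cc(OC)c1OC` differs from compound 3 by oxolan-2-yl in place of pentyl on a saturated chain carbon bound to an aromatic nitrogen. Among the measured compounds shown here, no measured step covers this exchange. The step of a 2.6-fold lower number from compound 1 to compound 2 (0.42 log units; beyond the scatter) concerns the same chain on the aromatic nitrogen, lengthening it toward a terminal hydroxy, and it bears on the present change only loosely. Taken together with the flat numbers of compound 1, compound 2 and compound 3, the expectation for this assay is no step beyond the scatter, with a slight lean toward a lower number in view of a 2.6-fold lower number from compound 1 to compound 2 (0.42 log units; beyond the scatter). The step from compound 3 to compound 4 is therefore expected at a 1.2-fold lower number from compound 3 to compound 4 (0.09 log units; within the scatter). Compound 4 is estimated at 90000000 nM, in the range 35000000 nM to 230000000 nM.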

Compound 4, half-maximal effective concentration: 147000000 nM
Compound 4: the middle estimate sits 1.6-fold (0.21 log units) below what was measured; low and high end bracket the measured number.
By their numbers in this assay, from the lowest: compounds 2, 3, 4 and 1 (each within the scatter of the next, the first and the last beyond it).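

At the saturated chain carbon bound to an aromatic nitrogen, oxolan-2-yl in place of pentyl puts a five-membered non-aromatic ring and a hydrogen-bond acceptor where compound 3 has neither, and this assay gives a 1.3-fold higher number from compound 3 to compound 4 (0.12 log units; within the scatter). Among these compounds, the earlier compounds carry only open chains at this place, with or without a terminal hydroxy, so this pair gives the first reading of a ring there, and on this read-out compound 4 cannot be told apart from compound 3. No measured evidence bears on this result, and the numbers alone do not explain it.

The step leaves open whether the ring or its oxygen matters at this place, a question that an open ether chain such as 2-methoxyethyl, holding the oxygen without the ring, or cyclopentylmethyl, holding the ring without the oxygen, would address directly. From the compounds shown here alone, it is also open whether a group of a different kind on this chain, such as an amine or a carboxylic acid, would give a step beyond the scatter from compound 3.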